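Swapping the aryl ring on the piperazine of a bornane sulfonamide

The source may report more compounds than this note shows. Statements on the series, on what has been measured and on what is new or still open speak of the compounds shown alone.

Measured compounds:
compound 1 `CC1(C)[C@@H]2CC[C@@]1(CS(=O)(=O)N1CCN(c3ncccc3C(F)(F)F)CC1)C(=O)C2`, > 31600 nM
compound 2 `C[C@@H]1CN(c2ccc(C(F)(F)F)cn2)[C@@H](C)CN1S(=O)(=O)C[C@]12CC[C@H](CC1=O)C2(C)C`, 6310 nM
compound 3 `C[C@H]1CN(S(=O)(=O)C[C@]23CC[C@H](CC2=O)C3(C)C)CCN1c1ccc(C(F)(F)F)cn1`, 158 nM

As far as these compounds go, in a functional assay on CHO-K1 cells for antagonist activity at C-X-C chemokine receptor type 3 (Homo sapiens), read by FLIPR and calcium flux (on this read-out higher numbers stand for weaker inhibition and lower numbers for stronger inhibition), compound 1 gives only a limit, > 31600 nM, so its true value is unknown beyond that. Compound 4 `CC1(C)[C@@H]2CC[C@@]1(CS(=O)(=O)N1CCN(c3ncc(C(F)(F)F)cn3)CC1)C(=O)C2` carries the change (5-(trifluoromethyl)pyrimidin-2-yl in place of 3-(trifluoromethyl)pyridin-2-yl on an amine nitrogen in a ring). Among the measured compounds shown here, none of the measured steps concerns this kind of change; the single measured step, a 40-fold lower number from compound 2 to compound 3 (1.60 log units; beyond the scatter), removes a methyl from a saturated ring and says nothing about the aryl ring. The aryl ring of compound 3 differs from that of compound 1; in this assay compound 3 gives 158 nM, and compound 2 gives 6310 nM, which only shows that this region of the molecule can reach measurable values. Compound 4 is therefore expected to land near 1500 nM, within 150 nM to 15000 nM, an estimated step of an at least 21-fold lower number from compound 1 to compound 4 (1.32 log units; beyond the scatter).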

Compound 4, half-maximal inhibitory concentration: 316 nM
Compound 4: the middle estimate sits 4.7-fold (0.68 log units) above what was measured; the range from low to high includes it.
By their numbers in this assay, from the lowest: compounds 3 and 4 (each within the scatter of the next); then compound 2. At a limit, above all of these: compound 1.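

In this assay, the aryl group on an amine nitrogen in a ring has a large effect on the shared core: 5-(trifluoromethyl)pyrimidin-2-yl in place of 3-(trifluoromethyl)pyridin-2-yl gives an at least 100-fold lower number from compound 1 to compound 4 (2.00 log units; beyond the scatter). The true size of this step remains unknown, because compound 1 stands at a limit of the assay: the limit of > 31600 nM in this assay, at which 1 of the 4 values shown sits.

The two aryl groups differ both in their number of ring hetero atoms and in the name-given position of the trifluoromethyl, and the compounds shown do not separate these two differences. Also open, as far as these compounds go, is whether a nitrile or a chlorine in place of the trifluoromethyl would keep a measurable value.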